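The source may report more compounds than this note shows. Statements on the series, on what has been measured and on what is new or still open speak of the compounds shown alone.

Of the compounds shown here, three have been measured so far in an assay on isolated protein for agonist activity at Bile acid receptor (Homo sapiens), read by AlphaScreen, with a stated time of 30 min; a lower number here means that less compound is needed, a higher number that more compound is needed for the effect. Compound 1 `Cc1ccccc1-n1nc(C)c2c1NC(=O)[C@H](C)S[C@@H]2c1ccc(-c2ccoc2)cc1` gives 3500 nM, which is the highest of the three numbers. Compound 2 `COc1ccccc1-c1ccc([C@H]2S[C@@H](C)C(=O)Nc3c2c(C)nn3-c2ccccc2C)cc1` gives 1100 nM, and compound 3 `Cc1nn(-c2ccccc2C(C)C)c2c1[C@@H](c1ccc(Oc3ccccc3)cc1)S[C@@H](C)C(=O)N2` gives 1900 nM; the gap between compound 1 and compound 3 lies within the usual scatter, so the two cannot be told apart.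

The new compound 4 `Cc1ccccc1-n1nc(C)c2c1NC(=O)[C@H](C)S[C@@H]2c1ccc(-c2ccccc2)cc1` is reached from compound 1 by a single change: phenyl in place of furan-3-yl on an aromatic carbon.

Going by the values given here, only one measured step bears on this change. Going a 3.2-fold lower number from compound 1 to compound 2 (0.50 log units; beyond the scatter) also replaced the furan-3-yl group, there by a 2-methoxyphenyl group, and brought a modest lowering of the number. Compound 4 carries a plain phenyl at the same place, so the same kind of exchange is made, but without the methoxy group; the data give no way to separate what the methoxy group itself contributed. A lowering of similar or somewhat smaller size is therefore expected in this assay.

Compound 4 is expected to give about 1800 nM, with a plausible range from 700 nM to 4500 nM. That estimate corresponds to an expected step of a 1.9-fold lower number from compound 1 to compound 4 (0.29 log units; within the scatter).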

Compound 4, half-maximal effective concentration: 990 nM
Compound 4: middle estimate off by 1.8-fold (0.26 log units), on the high side; measured number inside the range.
By their numbers in this assay, from the lowest: compounds 4, 2, 3 and 1 (each within the scatter of the next, the first and the last beyond it).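

In this assay a plain phenyl in place of furan-3-yl gives a 3.5-fold lower number from compound 1 to compound 4 (0.55 log units; beyond the scatter) and so lowers the number without any methoxy group, which compound 2 could not show because it brought the new ring and the methoxy group together. Removing the methoxy group gives a 1.1-fold lower number from compound 2 to compound 4 (0.05 log units; within the scatter) and leaves the two compounds indistinguishable, so at this place, para to a large group, the lowering goes with the exchange of furan-3-yl for a six-membered aromatic ring and the methoxy group adds nothing that can be detected. No measurement available here explains why this exchange lowers the number.

The compounds shown leave open whether a saturated cyclohexyl ring, a pyridine ring or a single chlorine atom at this place would give a number like that of the phenyl group. They also leave open how a carboxylic acid or an amine carried on the phenyl ring would shift the number, and whether the same exchange would have the same effect with other groups elsewhere on the shared core.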